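Phenyl for methyl on the fused core of compound 1

The source may hold more compounds than are shown below. What is called first, only, known or untested is meant among the compounds shown, and "the series" means these compounds.

Compound 1 `CC(=O)Nc1nc(-c2ccccc2)nc2nc(C)cn12` carries acetyl on a ring nitrogen of the shared core. In an assay on cell membranes for displacement of a labelled ligand from adenosine receptor A1 (Bos taurus) (on this read-out higher numbers stand for weaker inhibition and lower numbers for stronger inhibition), compound 1 gives 855 nM, the highest of the two numbers measured in the series. Compound 2 `CC(=O)CNc1nc(-c2ccccc2)nc2nc(C)cn12` gives 12 nM in this assay, a step of a 71-fold lower number from compound 1 to compound 2 (1.85 log units; beyond the scatter). Compound 3 `CCC(=O)CNc1nc(-c2ccccc2)nc2nc(C)cn12` gives only a limit in this assay, > 10000 nM. The steps of an at least 11-fold higher number from compound 1 to compound 3 (1.06 log units; beyond the scatter) and an at least 830-fold higher number from compound 2 to compound 3 (2.92 log units; beyond the scatter) both change the group on that ring nitrogen.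

Compound 4 `CC(=O)Nc1nc(-c2ccccc2)nc2nc(-c3ccccc3)cn12` differs from compound 1 by phenyl in place of methyl on an aromatic carbon. None of the three measured steps alters this position; all concern the group on the ring nitrogen, so they give no direct guide. For compound 4 no step beyond the scatter is therefore expected, and a wide range is kept: compound 4 is estimated at 850 nM, between 200 nM and 4000 nM, an expected step of a 1.0-fold lower number from compound 1 to compound 4 (0.00 log units; within the scatter).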

Compound 4, inhibition constant: 23 nM
For compound 4 the middle estimate is 37-fold (1.57 log units) above the measured one; the whole stated range lies above it.
By their numbers in this assay, from the lowest: compounds 2 and 4 (each within the scatter of the next); then compound 1. At a limit, above all of these: compound 3.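

In this assay, the aromatic carbon of the five-membered ring proves a sensitive position: phenyl in place of methyl gives a 37-fold lower number from compound 1 to compound 4 (1.57 log units; beyond the scatter). Among these compounds, all earlier steps changed the group on the ring nitrogen, so this is the first evidence that a change elsewhere on the shared core, with acetyl kept, also moves the number strongly. The data shown offer no explanation for this step.

Going by these compounds, whether phenyl has a similar effect with 2-oxopropyl on the nitrogen remains open. So does the outcome with ethyl at this carbon, or with a phenyl carrying an amine or a carboxylic acid.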